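Amide aryl exchange in the sulfonamide anilide series

The compounds below may be only part of what the source reports. "The series", "measured", "known", "first", "only" and "open" are said of these compounds alone.

Compound 2 `O=C(Nc1ccc(S(=O)(=O)Nc2ccccc2)cc1)c1ccc(Cl)cc1Br` gives 1020 nM in a functional assay on HEK293 cells for agonist activity at probable G-protein coupled receptor 27 (Homo sapiens), read by a luciferase reporter and beta-arrestin recruitment, with a stated time of 10 min; a lower number here means that less compound is needed, a higher number that more compound is needed for the effect. Compound 3 `O=C(Nc1ccc(S(=O)(=O)Nc2cccc(Cl)c2)cc1)c1ccc(Cl)cc1Cl` gives 575 nM in this assay; the two numbers lie within the usual scatter of each other, so neither can be set apart from the other. Compound 1 `O=C(Nc1cccc(S(=O)(=O)Nc2ccccc2)c1)c1ccc(Cl)cc1Cl` returns only a limit in this assay, > 100000 nM (the limit of > 100000 nM in this assay, at which 1 of the 3 values shown sits). Compound 4 `O=C(Nc1ccc(S(=O)(=O)Nc2ccccc2)cc1)c1cc(F)c(Cl)cc1F` has not yet been measured. It differs from compound 2 in one place: 4-chloro-2,5-difluorophenyl in place of 2-bromo-4-chlorophenyl on a carbonyl carbon. No measured pair in the set isolates a change of this kind on the carbonyl carbon, so the size of the step cannot be read from the numbers shown. The expectation is a step of modest size, most likely toward a higher number in this assay, though a result within the scatter of the value of compound 2 at 1020 nM remains plausible. Compound 4 is expected to give 1600 nM in this assay, within the range 400 nM to 6500 nM, an expected step of a 1.6-fold higher number from compound 2 to compound 4 (0.20 log units; within the scatter).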

Compound 4, half-maximal effective concentration: 141 nM
Beside the measured number, compound 4's estimate is 11-fold (1.05 log units) above it, outside the stated range (below it).
By their numbers in this assay, from the lowest: compound 4; then compounds 3 and 2 (each within the scatter of the next). At a limit, above all of these: compound 1.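

On the carbonyl carbon, the aryl group is not a silent place in this assay: 4-chloro-2,5-difluorophenyl in place of 2-bromo-4-chlorophenyl gives a 7.2-fold lower number from compound 2 to compound 4 (0.86 log units; beyond the scatter). Going by these compounds alone, this is the first step that isolates a change at this place, since the earlier compounds differ from each other in more than one place. Both groups are six-membered aromatic rings of carbon only with no net charge, so the step follows a change in halogens alone, and no measured property shown bears on why the number falls.

The compounds shown do not separate the removal of the bromine from the entry of the two fluorines. Also open, as far as these compounds go, is how the series responds on this carbonyl carbon to a non-halogen group, such as a nitrile or a methoxy on the ring.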